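A few compounds are considered here, and "the series" means these few. Any claim that something is new, unique, unknown or untested is made for them only; others in the source may bear on it.

Four closely related compounds are compared here. Compound 1, `COC(=O)N(C)CC#CCn1ccnc1`, was tested in a functional assay on the whole organism for agonist activity, with Mus musculus as the target (a lower number here means that less compound is needed, a higher number that more compound is needed for the effect), and in this assay compound 1 gives 4.5 mg/kg. Compound 2, `COC(=O)N(C)CC#CCn1cncc1C`, carries one change relative to compound 1: methyl in place of hydrogen on an aromatic carbon. In this assay compound 2 reaches only a limit of the assay, > 100 mg/kg, and not a number. That single change produced an at least 22-fold higher number from compound 1 to compound 2 (1.34 log units; beyond the scatter). Compound 3, `CCOC(=O)N(C)CC#CCn1ccnc1`, differs from compound 1 in the core by methyl in place of hydrogen on a saturated chain carbon bound to an oxygen next to a carbonyl group. In this assay compound 3 likewise gives only a limit, > 100 mg/kg, not a number. Here too the step is an at least 22-fold higher number from compound 1 to compound 3 (1.34 log units; beyond the scatter). Both limits sit at the limit of > 100 mg/kg in this assay, at which 2 of the 3 values shown sit.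

Compound 4, `CCOC(=O)N(C)CC#CCn1cncc1C`, has not yet been measured in this assay. It differs from compound 3 by methyl in place of hydrogen on an aromatic carbon, which is the same change that separates compound 1 from compound 2. Compound 3 itself already stands at a limit in this assay, > 100 mg/kg. Adding to compound 3 the change that gave an at least 22-fold higher number from compound 1 to compound 2 (1.34 log units; beyond the scatter) between compound 1 and compound 2 offers no reason to expect a return to a measurable dose, so compound 4 is expected to give 300 mg/kg, a step estimated as a step that the limit leaves unreadable from compound 3 to compound 4. For compound 4 the expected range runs from 100 mg/kg to 1000 mg/kg, with a limit rather than a number the most likely outcome.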

Compound 4, dose for half-maximal effect: > 100 mg/kg
Compound 4 ended at the assay's limit (the forecaster's own chance of this, stated with the estimate: 90%); the middle value lies beyond the limit too.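

Compound 4 stops at a limit of this assay, just as compound 2 and compound 3 do, so no new step can be read from compound 4 to either of them: the limit of > 100 mg/kg in this assay, at which 3 of the 4 values shown sit.

As far as these compounds go, how far past that limit compound 2, compound 3 and compound 4 lie stays open, and with it whether the two methyl changes together do more than either change alone.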